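From propyl to hexyl at the assay limit

This account rests on a few compounds, and the source may have more. Where it says the series, first, only, none or still open, it means among the compounds named here.

In an ADME assay on CCRF-HSB-2 cells (Homo sapiens) for cytotoxicity, with a stated time of 7 days (on this read-out lower numbers stand for higher toxicity in this test and higher numbers for lower toxicity in this test), compound 1 (`Nc1nc(OCC(F)(F)F)c2ncn(/C=C3/CC3(CO)CO)c2n1`) reads > 20000 nM as a limit of the assay. Compound 2 (`CCCOc1nc(N)nc2c1ncn2/C=C1/CC1(CO)CO`) reads > 20000 nM as a limit too. Among the compounds with values here, the picture so far is the limit of > 20000 nM in this assay, at which 2 of the 2 values shown sit, and the one measured step (a step that the two limits leave unreadable from compound 1 to compound 2) gives no size to carry forward. Compound 3 (`CCCCCCOc1nc(N)nc2c1ncn2/C=C1/CC1(CO)CO`) differs from compound 2 by propyl in place of hydrogen on a saturated chain carbon, three bonds along the chain from an oxygen on an aromatic ring and in words this is propyl in place of hydrogen on a saturated chain carbon. No shift beyond the scatter is expected in either direction, so the estimated step is a number no higher from compound 2 to compound 3 (the limit leaves the size open) at most in name only. For compound 3 the expected value is 20000 nM within an estimated range of 8000 nM to 40000 nM and it may again be only a limit.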

Compound 3, half-maximal cytotoxic concentration: > 20000 nM
Compound 3 was reported as a limit; the forecaster's own chance of this, stated with the estimate: 70%; the middle value sits exactly at the limit.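

No step among compound 1, compound 2 and compound 3 can be read, since each value is only a limit of the assay: the limit of > 20000 nM in this assay, at which 3 of the 3 values shown sit.

As far as these compounds go, whether these three compounds differ at all in this assay stays open.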